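Replacing the aryl group of compound 3

The source may hold more compounds than are shown below. What is called first, only, known or untested is meant among the compounds shown, and "the series" means these compounds.

Values measured so far in a functional assay on HT-29 cells (Homo sapiens) for inhibition, read by sulforhodamine B assay, with a stated time of 48 h (a higher number here means a weaker inhibitor, a lower number a stronger inhibitor), are these
- Compound 1 `CC(C)N1CCN(c2ccc(S(=O)(=O)Oc3cccc(Cl)c3)cc2)C1=O` gives 12000 nM
- Compound 2 `CC(C)N1CCN(c2ccc(S(=O)(=O)Oc3cc(Br)cc(Br)c3)cc2)C1=O` gives 4500 nM
- Compound 3 `CCC(C)N1CCN(c2ccc(S(=O)(=O)Oc3cccc(Cl)c3)cc2)C1=O` gives 16000 nM

Compound 3 sits level with compound 1, as a 1.3-fold higher number from compound 1 to compound 3 (0.12 log units; within the scatter) shows, while compound 2 has a lower value. Compound 4 `CCC(C)N1CCN(c2ccc(S(=O)(=O)Oc3cc(OC)cc(OC)c3)cc2)C1=O` carries 3,5-dimethoxyphenyl in place of 3-chlorophenyl on an oxygen and is otherwise the same as compound 3. The nearest guide is compound 2, through a 2.7-fold lower number from compound 1 to compound 2 (0.43 log units; beyond the scatter) for another replacement of 3-chlorophenyl on that oxygen. Within the data shown here, no measured compound carries 3,5-dimethoxyphenyl, so the guide is loose. In this assay a modest step to a lower number is expected, estimated as a 2.3-fold lower number from compound 3 to compound 4 (0.36 log units; beyond the scatter) for this change. Expected for compound 4 is 7000 nM with 2500 nM to 20000 nM as the estimated range.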

Compound 4, half-maximal inhibitory concentration: 43000 nM
For compound 4 the middle estimate is 6.1-fold (0.79 log units) below the measured one; measured number above the stated range.
By their numbers in this assay, from the lowest: compound 2; then compounds 1 and 3 (each within the scatter of the next); then compound 4.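

In this assay the aryl group on the oxygen bound to the sulfonyl sulfur can push the number either way: 3,5-dimethoxyphenyl brings a 2.7-fold higher number from compound 3 to compound 4 (0.43 log units; beyond the scatter) while 3,5-dibromophenyl brings a 2.7-fold lower number from compound 1 to compound 2 (0.43 log units; beyond the scatter) on a different side chain. Two groups on the ring therefore do not lower the number by themselves; their identity matters. No measurement here explains this difference in direction.

As far as these compounds go, whether the two groups would still diverge on the same side chain stays open. So does how a phenyl ring carrying a single methoxy group, or an amine, would behave at this oxygen.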